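Acetate removed from a sugar-linked nitrophenyl oxadiazole

The compounds below may be only part of what the source reports. "The series", "measured", "known", "first", "only" and "open" are said of these compounds alone.

For the measured compounds named here, compound 1 `CC(=O)OC[C@H]1O[C@@H](OCc2noc(-c3ccc([N+](=O)[O-])cc3)n2)[C@@H]2OC3(CCCC3)O[C@@H]21` is the only compound of this set with a numbered result: in a functional assay on A549 cells (Homo sapiens) for antiproliferative activity, read by sulforhodamine B assay, with a stated time of 48 h (a higher number here means a weaker inhibitor of growth, a lower number a stronger inhibitor of growth), compound 1 gives 29000 nM. Compound 2 `CC1(C)O[C@H]2[C@H](OCc3noc(-c4ccc([N+](=O)[O-])cc4)n3)O[C@H](CSc3nnc(N)s3)[C@H]2O1` is the second compound of the set. In this assay compound 2 gives > 100000 nM, which is a limit of the assay and not a number (the limit of > 100000 nM in this assay, at which 1 of the 2 values shown sits). Going by the values given here, no step between measured compounds that differ in one place is available, so the two values are only set beside each other.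

Compound 3 `O=[N+]([O-])c1ccc(-c2nc(CO[C@@H]3O[C@H](CO)[C@H]4OC5(CCCC5)O[C@@H]34)no2)cc1` is not yet measured. It differs from compound 1 in one place: hydrogen in place of acetyl on an oxygen on a saturated carbon. The core of compound 1 and the nitrophenyl oxadiazole are kept unchanged.

Among the compounds with values here, since no measured step tells how this change acts, the expected step from compound 1 to compound 3 is small: a 1.2-fold higher number from compound 1 to compound 3 (0.08 log units; within the scatter) is estimated to lie within or near the scatter, with no firm direction. Compound 3 is therefore expected to give about 35000 nM in this assay, within a range from 12000 nM to 100000 nM.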

Compound 3, concentration for 50% growth inhibition: 32000 nM
Estimate against measurement, compound 3: 1.1-fold (0.04 log units) above; measured number inside the range.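

In this assay, for the compounds shown here, the change from acetoxymethyl to hydroxymethyl gives the first step in this set that can be read between two measured compounds (a 1.1-fold higher number from compound 1 to compound 3 (0.04 log units; within the scatter)), and that step lies within the scatter. For this pair, then, the acetyl on the oxygen is not required for the antiproliferative activity seen with compound 1, and a free hydroxy at the same place gives a result that cannot be told apart from it. Nothing in the data shown explains this outcome.

From the compounds shown here alone, it remains open whether a different group on this oxygen, such as a benzoyl ester or a methyl ether, or an amine in place of the hydroxy, would move the number beyond the scatter. Also open, going by these compounds, is how the values would respond to a change in the part kept fixed in this step, for example an amine or a carboxylic acid in place of the nitro group on the nitrophenyl oxadiazole.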